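The compounds below may be only part of what the source reports. "The series", "measured", "known", "first", "only" and "open" are said of these compounds alone.

Compound 1 `Cc1ccc(NC(=O)/C=C/c2ccccc2)c(C(N)=O)c1`: 65.4%
Compound 2 `NC(=O)c1cc(Cl)ccc1NC(=O)/C=C/c1cccc(Br)c1`: 27%

In a functional assay on K562 cells (Homo sapiens) for antiproliferative activity, read by trypan blue exclusion, with a stated time of 48 h, tested at 10 uM (on this read-out lower numbers stand for less inhibition of growth and higher numbers for more inhibition of growth at the one concentration tested), compound 2 gives 27% and compound 1 gives 65.4%. Compound 2 stands lowest of the two measured compounds, and its gap to compound 1 lies beyond the scatter. Compound 3 `Cc1cccc(/C=C/C(=O)Nc2ccc(Cl)cc2C(N)=O)c1` comes from compound 2 by methyl in place of bromo on an aromatic carbon. Going by the values given here, no measured pair isolates this change, since compound 1 and compound 2 differ in more than one place. In this assay a small upward step, not beyond the scatter, is expected. The expected step is a number 6 percentage points higher from compound 2 to compound 3 (within the scatter). For compound 3 the estimate is 33%, with a range from 15% to 55%.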

Compound 3, percent growth inhibition at one concentration: 37.8%
The estimate for compound 3 lay 4.8 percentage points below the measured number; the range from low to high includes it.
By their numbers in this assay, from the lowest: compound 2; then compound 3; then compound 1.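

In this assay, going by these compounds alone, methyl in place of bromo on an aromatic carbon gives a number 10.8 percentage points higher from compound 2 to compound 3 (beyond the scatter) as the first step that isolates a single change. This position, meta to a large group, therefore responds to an exchange of one heavy atom for another, with no hydrogen-bond donor, hydrogen-bond acceptor or net charge entering or leaving. No data at hand bear on the cause of this step. As far as these compounds go, whether an amine, a carboxylic acid or a longer chain at this position would raise or lower growth inhibition remains open. From the compounds shown here alone, whether the same exchange gives a similar step elsewhere on the shared core also remains open.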